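The compounds below may be only part of what the source reports. "The series", "measured", "known", "first", "only" and "open" are said of these compounds alone.

Compound 2 `O=C1Nc2ccc(C(=O)c3ccco3)cc2/C1=C/c1cc(Br)cc(Br)c1` carries the shared core of this pair with a 3,5-dibromophenyl on a double-bonded chain carbon bound to a double-bonded ring carbon. In an assay on HeLa cells for inhibition of Kinesin-like protein KIF15 (Homo sapiens), read by microscopy, with stated times of 2 s and 20 s, tested at 750 nM (on this read-out lower numbers stand for less inhibition and higher numbers for more inhibition at the one concentration tested (going by the name of the read-out)), compound 2 gives 16%, the lowest of the two numbers seen so far. Compound 1 `O=C1Nc2ccc(C(=O)c3ccco3)cc2/C1=C/c1cc(F)c(O)c(Br)c1` is its nearest neighbour: in this assay compound 1 gives 38%, and the step of a number 22 percentage points lower from compound 1 to compound 2 (beyond the scatter) is the only measured one that bears on the change now in view. Compound 3 `Cc1cc(/C=C2\C(=O)Nc3ccc(C(=O)c4ccco4)cc32)cc(C)c1O` is not yet measured. It differs from compound 2 by 4-hydroxy-3,5-dimethylphenyl in place of 3,5-dibromophenyl on a double-bonded chain carbon bound to a double-bonded ring carbon. The entering group brings back a hydroxyl, one hydrogen-bond donor and one hydrogen-bond acceptor, which compound 2 lacks and compound 1 has, while the two bromines give way to two methyls. Because the step of a number 22 percentage points lower from compound 1 to compound 2 (beyond the scatter) went with the loss of that hydroxyl, compound 3 is expected to move back upward in this assay, by an estimated a number 18 percentage points higher from compound 2 to compound 3 (beyond the scatter), though the methyls in place of the halogens leave the size uncertain. Compound 3 is therefore estimated at 34% in this assay, with a range from 14% to 54%.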

Compound 3, a percentage reported as inhibition, at one concentration (the size of the read-out at that concentration, not a potency): 9%
Compound 3: middle estimate off by 25 percentage points, on the high side, outside the stated range (below it).
By their numbers in this assay, from the lowest: compounds 3 and 2 (each within the scatter of the next); then compound 1.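

In this assay, the step is a number 7 percentage points lower from compound 2 to compound 3 (within the scatter), so 4-hydroxy-3,5-dimethylphenyl and 3,5-dibromophenyl cannot be told apart at this position, on a double-bonded chain carbon bound to a double-bonded ring carbon. Compound 1 and compound 3 both carry a hydroxyl, yet the step is a number 29 percentage points lower from compound 1 to compound 3 (beyond the scatter), so among these three compounds a hydroxyl alone does not go with the higher number, and compound 3 stands against the link suggested by the first pair. What sets compound 1 apart therefore appears to lie in the whole substituted ring rather than in the hydroxyl alone, and nothing available explains this difference.

On these data alone, it remains open whether the fluorine, the bromine or their combination with the hydroxyl accounts for the higher number of compound 1. Also unresolved is how an amine or a carboxylic acid in place of that hydroxyl would read, and, with only one concentration tested, these numbers say nothing about potency.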